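The compounds below may be only part of what the source reports. "The series", "measured", "known", "first", "only" and "open" are said of these compounds alone.

Working notes on the series.

Two members of the series have been tested in a functional assay on HeLa cells (Homo sapiens) for inhibition, read by MTT assay, with a stated time of 72 h; a lower number here means a stronger inhibitor, a higher number a weaker inhibitor. Compound 1, `CN(C(=O)NC(=O)c1ccc(F)c(F)c1)c1nc(C(F)(F)F)c(C(=O)N/N=C/c2ccccc2C(F)(F)F)s1`, gives 9.24 ug/mL in this assay. Going by the values given here, compound 2, `CN(C(=O)NC(=O)c1c(F)cccc1F)c1nc(C(F)(F)F)c(C(=O)N/N=C/c2ccccc2C(F)(F)F)s1`, gives 19.6 ug/mL in this assay, and so stands as the higher of the two numbers measured so far; its nearest neighbour is compound 1, and the only step recorded, a 2.1-fold higher number from compound 1 to compound 2 (0.33 log units; beyond the scatter), lies beyond the scatter but is modest in size.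

Compound 3, `CN(C(=O)NC(=O)c1cccc([N+](=O)[O-])c1)c1nc(C(F)(F)F)c(C(=O)N/N=C/c2ccccc2C(F)(F)F)s1`, has not yet been measured. It differs from compound 2 by 3-nitrophenyl in place of 2,6-difluorophenyl on a carbonyl carbon. Among the compounds with values here, the one measured step that touches this position is a 2.1-fold higher number from compound 1 to compound 2 (0.33 log units; beyond the scatter), which swapped one fluorine pattern on that phenyl for another and moved the number only modestly. Within the data shown here, no step yet exchanges a difluorophenyl for a nitrophenyl, so the direction of the change cannot be read from the data. Among the measured compounds shown here, from the size of the only comparable step, the expected step of a 1.4-fold lower number from compound 2 to compound 3 (0.15 log units; within the scatter) is small, and compound 3 is estimated at 14 ug/mL in this assay, with a range from 5 ug/mL to 40 ug/mL.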

Compound 3, half-maximal inhibitory concentration: 4.15 ug/mL
Compound 3: the middle estimate sits 3.4-fold (0.53 log units) above what was measured; measured number outside the range, below it.
By their numbers in this assay, from the lowest: compound 3; then compound 1; then compound 2.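

Going by these compounds alone, compound 3 brings the first group at this position that is not a difluorophenyl, and the exchange for 3-nitrophenyl on the carbonyl carbon gives a 4.7-fold lower number from compound 2 to compound 3 (0.67 log units; beyond the scatter) in this assay and, against the other fluorine pattern, a 2.2-fold lower number from compound 1 to compound 3 (0.35 log units; beyond the scatter). Both steps are beyond the scatter and both point the same way, so compound 3 is the strongest inhibitor of the three, and the position is shown to do more than respond to the rearrangement of two fluorines: a group with two hydrogen-bond acceptors, entering where the difluorophenyl groups have none, is accommodated with a lower number than either of them. Nothing measured alongside these numbers accounts for the change, so the result stands as an observation only.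

With one nitrophenyl in hand, the compounds shown cannot separate the contribution of the nitro group from that of the loss of the fluorines, and an unsubstituted phenyl would be the direct reference for both. Going by these compounds, it also remains open whether a phenyl carrying an amine or a carboxylic acid would follow compound 3, or whether the lower number is particular to the nitro group.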